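From tert-butyl to cyclobutyl on a shared core

The source may hold more compounds than are shown below. What is called first, only, known or untested is meant among the compounds shown, and "the series" means these compounds.

Measured so far in a physicochemical assay for solubility, in phosphate buffer, at pH 6.8 (a higher number here means a more soluble compound, a lower number a less soluble compound), are three compounds:
compound 1 `CCn1c(NC(C)(C)C)nc2ccsc2c1=O` at 3.7 ug/mL
compound 2 `CCn1c(NC(C)C)nc2c(-c3cccnc3)csc2c1=O` at 5.8 ug/mL
compound 3 `CCn1c(NC(C)C)nc2c(-c3ccco3)csc2c1=O` at 0.1 ug/mL

Compound 1 at 3.7 ug/mL lies within the scatter of compound 2 at 5.8 ug/mL and stands well clear of compound 3 at 0.1 ug/mL on the high side. Compound 4 `CCn1c(NC2CCC2)nc2ccsc2c1=O` has cyclobutyl in place of tert-butyl on a nitrogen on an aromatic ring and is otherwise the same. Going by the values given here, the only measured step is a 58-fold lower number from compound 2 to compound 3 (1.76 log units; beyond the scatter) and, large as it is, it concerns furan-2-yl in place of pyridin-3-yl on an aromatic carbon. Among the compounds with values here, no measured step therefore bears on this change, and in this assay nothing beyond the scatter is expected, in no firm direction. The expected step is a 1.2-fold higher number from compound 1 to compound 4 (0.09 log units; within the scatter) and it rests on compound 1 alone. For compound 4 the estimated value is 4.5 ug/mL with an expected range of 1.5 ug/mL to 13 ug/mL in this measurement.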

Compound 4, solubility: 6.3 ug/mL
Compound 4: the middle estimate sits 1.4-fold (0.15 log units) below what was measured; the measured number falls inside the stated range.
By their numbers in this assay, from the lowest: compound 3; then compounds 1, 2 and 4 (each within the scatter of the next).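

In this assay this change now has a measured step, a 1.7-fold higher number from compound 1 to compound 4 (0.23 log units; within the scatter), so on the shared core cyclobutyl in place of tert-butyl on a nitrogen on an aromatic ring stays inside the scatter. At this position, a four-membered ring of carbon is thus tolerated in this read-out without a change that can be told from the scatter. No supporting measurement bears on this result.

Going by these compounds, whether a longer chain or a cyclobutyl carrying an amine or a carboxylic acid would go beyond the scatter remains open. So does whether this change reads the same with pyridin-3-yl or furan-2-yl on an aromatic carbon.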